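Replacing a cyclopropyl with a fluorinated pyridyl ring

The source may report more compounds than this note shows. Statements on the series, on what has been measured and on what is new or still open speak of the compounds shown alone.

Measured compounds:
Compound 1, `Nc1ccc(S(=O)(=O)N2CCN(c3ncc(C(O)(C(F)(F)F)C(F)(F)F)cc3C3CC3)CC2)cn1`: 27 mL.min-1.g-1
Compound 2, `Nc1ccc(S(=O)(=O)N2CCN(c3ncc(C(O)(C(F)(F)F)C(F)(F)F)cc3-c3cccc(F)c3)CC2)cn1`: 52 mL.min-1.g-1
Compound 3, `Nc1ccc(S(=O)(=O)N2CCN(c3ncc(C(O)(C(F)(F)F)C(F)(F)F)cc3-c3cccnc3)CC2)cn1`: 20 mL.min-1.g-1

All three compounds were tested in an ADME assay (liver) for metabolic stability, with Liver microsome (Rattus norvegicus) as the target, using microsomes and NADPH, with a stated time of 30 min, tested at 1 uM; on this read-out higher numbers stand for fast clearance and lower numbers for slow clearance. Compound 1 stands second highest of the three numbers. Its nearest neighbour is compound 3, which sits a 1.4-fold lower number from compound 1 to compound 3 (0.13 log units; within the scatter), and the furthest is compound 2, which sits a 1.9-fold higher number from compound 1 to compound 2 (0.28 log units; within the scatter); both of these steps lie within the scatter. Going by the values given here, the one step beyond the scatter is a 2.6-fold lower number from compound 2 to compound 3 (0.41 log units; beyond the scatter), a modest one.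

The new compound 4, `Nc1ccc(S(=O)(=O)N2CCN(c3ncc(C(O)(C(F)(F)F)C(F)(F)F)cc3-c3cnccc3F)CC2)cn1`, differs from compound 1 in one place: 4-fluoropyridin-3-yl in place of cyclopropyl on an aromatic carbon. Among the compounds with values here, the steps that bear on it are the two in which the cyclopropyl of compound 1 is exchanged for an aromatic ring: the 3-fluorophenyl of compound 2 and the pyridin-3-yl of compound 3. Neither moved the number beyond the scatter, and the 4-fluoropyridin-3-yl that enters shares its ring nitrogen with the pyridin-3-yl of compound 3, whose value is 20 mL.min-1.g-1. No step beyond the scatter is therefore expected from compound 1 to compound 4 in this assay.

The estimate for compound 4 is 25 mL.min-1.g-1, with a range from 12 mL.min-1.g-1 to 50 mL.min-1.g-1, which would mean an expected step of a 1.1-fold lower number from compound 1 to compound 4 (0.03 log units; within the scatter).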

Compound 4, intrinsic clearance in microsomes: 22 mL.min-1.g-1
Estimate against measurement, compound 4: 1.1-fold (0.06 log units) above; measured number inside the range.
By their numbers in this assay, from the lowest: compounds 3, 4, 1 and 2 (each within the scatter of the next, the first and the last beyond it).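

In this assay, fluoro in place of hydrogen on the pyridine ring gives a 1.1-fold higher number from compound 3 to compound 4 (0.04 log units; within the scatter), the only step shown that isolates a fluoro on a ring at this position, and the full exchange of the cyclopropyl for 4-fluoropyridin-3-yl gives a 1.2-fold lower number from compound 1 to compound 4 (0.09 log units; within the scatter). Against the 3-fluorophenyl ring, the same 4-fluoropyridin-3-yl gives a 2.4-fold lower number from compound 2 to compound 4 (0.37 log units; beyond the scatter), so among these compounds a fluoro on the ring does not by itself go with the high number of compound 2: compound 4 carries one too, and the pair of ring systems that differ by a ring nitrogen stands apart much as compound 3 does from compound 2. The data shown offer no measurement that accounts for these numbers.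

The compounds shown leave open whether a ring carrying an amine or a methoxy group at this carbon would stay within the same narrow band. They also leave open what a fluoro at another carbon of the pyridine ring, or a saturated ring such as morpholine in place of the aromatic rings, would do to the number.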